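The compounds below may be only part of what the source reports. "The series", "measured", "known", "first", "only" and "open" are said of these compounds alone.

Measured compounds:
- compound 1 `COc1ccc(S(=O)(=O)N2CCc3cccc(NC(=O)c4ccncc4)c32)cc1`: 9.4 nM in a functional assay on NCI-H460 cells (Homo sapiens) for cytotoxicity; on this read-out higher numbers stand for weaker inhibition and lower numbers for stronger inhibition
- compound 2 `COc1ccc(S(=O)(=O)N2CCc3cccc(NCc4ccccc4)c32)cc1`: > 10000 nM in this assay, a limit of the assay rather than a number

Among the compounds with values here, the one measured step runs from an amide to an amine on the ring nitrogen: benzyl in place of (pyridin-4-yl)carbonyl gives an at least 1000-fold higher number from compound 1 to compound 2 (3.02 log units; beyond the scatter). Compound 2 stands at the floor of what the assay reports (the limit of > 10000 nM in this assay, at which 1 of the 2 values shown sits), so the true size of that step is open at the upper end.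

Compound 3 `COc1ccc(S(=O)(=O)N2CCc3cccc(NC(=O)c4ccccc4)c32)cc1` keeps the benzyl ring of compound 2 but changes the linkage: benzoyl in place of benzyl on a nitrogen on an aromatic ring. The step thus brings back the carbonyl that the step from compound 1 to compound 2 removed, while the pyridine nitrogen of compound 1 stays absent. Within the data shown here, the only bearing step, from compound 1 to compound 2, is large and in the loss direction; its reversal in the carbonyl alone is expected to recover much of the lost potency, with the uncertainty lying in how much the missing ring nitrogen costs. Compound 3 is therefore expected to show a large step down, an at least 200-fold lower number from compound 2 to compound 3 (2.30 log units; beyond the scatter), to about 50 nM, with a likely range from 6 nM to 1500 nM.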

Compound 3, half-maximal inhibitory concentration: 257 nM
Compound 3: the middle estimate sits 5.1-fold (0.71 log units) below what was measured; the measured number falls inside the stated range.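

With the phenyl ring held, benzoyl in place of benzyl on a nitrogen on an aromatic ring gives an at least 38-fold lower number from compound 2 to compound 3 (1.59 log units; beyond the scatter) in this assay, so the carbonyl by itself accounts for a large change at this nitrogen, which the earlier pair could not show because the ring and the linkage changed together there. From the compounds shown here alone, the value of compound 2 is a limit and not a number, so the true size of that step stays open at one end: the limit of > 10000 nM in this assay, at which 1 of the 3 values shown sits. With the carbonyl held, phenyl in place of pyridin-4-yl on a carbonyl carbon gives a 27-fold higher number from compound 1 to compound 3 (1.44 log units; beyond the scatter), so the ring on the carbonyl also matters in its own right, and the amide link alone does not restore the level of the pyridine amide.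

The compounds shown leave open whether this difference is tied to the ring nitrogen at that particular place or would also appear with a pyridin-3-yl or pyrimidinyl ring on the carbonyl carbon. Going by these compounds, it also remains open how a (pyridin-4-yl)methyl group on the same nitrogen, or a sulfonyl link in place of the carbonyl, would read out.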